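A few compounds are considered here, and "the series" means these few. Any claim that something is new, unique, unknown or untested is made for them only; others in the source may bear on it.

Working notes on the series. Compound 2 `COC(=O)[C@@]1(C)CCC=C2[C@@H]1CC[C@@H](C)[C@]2(C)Cc1c(C)[nH]c2ccc(F)cc12` gives 14000 nM in a functional assay on HBL-100 cells (Homo sapiens) for inhibition, read by sulforhodamine B assay, with a stated time of 48 h; on this read-out higher numbers stand for weaker inhibition of growth and lower numbers for stronger inhibition of growth. Compound 1 `COC(=O)[C@@]1(C)CCC=C2[C@@H]1CC[C@@H](C)[C@]2(C)Cc1c(C)[nH]c2ccccc12` gives 14000 nM in this assay. The step of no change at the digits printed from compound 1 to compound 2 (within the scatter) lies within the scatter, so compound 2 stands level with compound 1 on the numbers shown. Compound 3 `COC(=O)[C@@]1(C)CCC=C2[C@@H]1CC[C@@H](C)[C@]2(C)Cc1c(C)[nH]c2ccc(C(F)(F)F)cc12` differs from compound 2 by trifluoromethyl in place of fluoro on an aromatic carbon. Of the measured steps only no change at the digits printed from compound 1 to compound 2 (within the scatter) bears on this change, and it was flat, so no step beyond the scatter is expected in this assay for compound 3. Compound 3 is estimated at 14000 nM, with a range from 7000 nM to 28000 nM. This corresponds to an expected step of no change at the digits printed from compound 2 to compound 3 (within the scatter).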

Compound 3, concentration for 50% growth inhibition: 16000 nM
Estimate against measurement, compound 3: 1.1-fold (0.06 log units) below; the measured number falls inside the stated range.
By their numbers in this assay, from the lowest: compounds 1, 2 and 3 (each within the scatter of the next).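

In this assay, trifluoromethyl at this aromatic carbon gives a 1.1-fold higher number from compound 2 to compound 3 (0.06 log units; within the scatter), and against hydrogen it gives a 1.1-fold higher number from compound 1 to compound 3 (0.06 log units; within the scatter). The position therefore now holds hydrogen, fluoro and trifluoromethyl, the last with 4 heavy atoms against 1 for fluoro, with no step beyond the scatter among compounds 1, 2 and 3. Nothing at hand explains this flat reading. From the compounds shown here alone, whether an amine or a carboxylic acid at this carbon would shift the number remains open. So does whether replacing the methyl ester elsewhere on the shared core with a carboxylic acid or an amide would do so.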